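Swapping the aryl group of compound 1

The source may hold more compounds than are shown below. What is called first, only, known or untested is meant among the compounds shown, and "the series" means these compounds.

Compound 1 `CC(=O)OCc1cc(C)cc(-c2c(O)nc3cc(Cl)c([N+](=O)[O-])cc3c2OCCC2CCCCN2)c1` gives 45 nM in a functional assay on cells (Pituitary gland cell) for antagonist activity at Gonadotropin-releasing hormone receptor (Rattus norvegicus) (on this read-out lower numbers stand for stronger inhibition and higher numbers for weaker inhibition), the second highest of three numbers. Compound 2 `O=C(Nc1cc2c(OCCC3CCCCN3)c(-c3ccc4ccccc4c3)c(O)nc2cc1Cl)NC1CC1` gives 68 nM, within the scatter of compound 1, while compound 3 `Cc1ccc(-c2c(O)nc3cc(Cl)c(NC(=O)NC4CC4)cc3c2OCCC2CCCCN2)cc1C` gives 6 nM, a clearly lower number. Compound 4 `O=[N+]([O-])c1cc2c(OCCC3CCCCN3)c(-c3cc(Cl)cc(Cl)c3)c(O)nc2cc1Cl` differs from compound 1 in one place: 3,5-dichlorophenyl in place of 3-(acetoxymethyl)-5-methylphenyl on an aromatic carbon. Among the measured compounds shown here, the only measured step that changes the same aryl ring is an 11-fold lower number from compound 2 to compound 3 (1.05 log units; beyond the scatter), a large shift, so changing this ring can move the number a long way. For the measured compounds named here, on that basis the step expected is a 2.3-fold lower number from compound 1 to compound 4 (0.35 log units; beyond the scatter), towards a lower number, though with wide uncertainty since no measured pair has this exact pair of rings. Compound 4 is therefore expected to give 20 nM, with a range from 5 nM to 80 nM.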

Compound 4, half-maximal inhibitory concentration: 24 nM
Beside the measured number, compound 4's estimate is 1.2-fold (0.08 log units) below it, and the stated range covers the measured number.
By their numbers in this assay, from the lowest: compound 3; then compounds 4, 1 and 2 (each within the scatter of the next, the first and the last beyond it).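

In this assay, replacing 3-(acetoxymethyl)-5-methylphenyl with 3,5-dichlorophenyl gives a 1.9-fold lower number from compound 1 to compound 4 (0.27 log units; within the scatter). Changes on this ring can therefore be large or small, and on this core a ring with no hydrogen-bond acceptors and fewer heavy atoms stays within the scatter of the larger ring with two acceptors. No evidence here explains this result.

On these data alone, whether an amine or a carboxylic acid on this ring would keep the number in this range remains open. So does whether the same swap would give a similar step on the core of compound 3.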